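Trimming the urea side chain of compound 1 to a methyl

The compounds below may be only part of what the source reports. "The series", "measured", "known", "first", "only" and "open" are said of these compounds alone.

Of the compounds shown here, three of a shared core have been measured in an assay on CHO cells for displacement of a labelled ligand from adenosine receptor A1 (Homo sapiens), read by scintillation counting, with a stated time of 120 min, tested at 1 uM; a lower number here means less inhibition, a higher number more inhibition at the concentration tested (going by the name of the read-out). Compound 1 `Cc1nc(NC(=O)NCc2ccccc2)c2nn(-c3ccccc3)cc2n1` gives 26% in this assay and stands highest of the three. Compound 2 `COc1ccc(-n2cc3nc(-c4ccccc4)nc(N)c3n2)cc1` gives 12%, a number below that of compound 1 by more than the usual scatter. Compound 3 `O=C(c1ccco1)N(C(=O)c1ccco1)c1nc(-c2ccccc2)nc2cn(-c3ccccc3)nc12` gives 3%, lowest of the set and also beyond the scatter from compound 1. Going by the values given here, no pair among the measured compounds differs in one place only, so no single-point step is available.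

Compound 4 `CC(=O)Nc1nc(C)nc2cn(-c3ccccc3)nc12` is not yet measured. It differs from compound 1 as follows: methyl in place of benzylamino on a carbonyl carbon. The change removes the only aromatic ring outside the shared core and the hydrogen-bond donor that sat on the carbonyl side chain.

Since compound 1 is the only measured compound carrying this side chain, the effect of removing it cannot be read from a shown step. The expectation is that the step from compound 1 to compound 4 is a drop in this assay, possibly beyond the scatter, of about a number 14 percentage points lower from compound 1 to compound 4 (beyond the scatter). Compound 4 is therefore estimated to give 12% in this assay, within a range from 0% to 30%.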

Compound 4, a percentage reported as inhibition, at one concentration (the size of the read-out at that concentration, not a potency): 25%
Beside the measured number, compound 4's estimate is 13 percentage points below it; measured number inside the range.
By their numbers in this assay, from the lowest: compounds 3 and 2 (each within the scatter of the next); then compounds 4 and 1 (each within the scatter of the next).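

In this assay, going by these compounds alone, the change of benzylamino to methyl on a carbonyl carbon gives a number 1 percentage points lower from compound 1 to compound 4 (within the scatter) and provides the first step in this set that differs in one place only. At the single concentration tested, the reading therefore does not depend on keeping benzylamino at this place: its six-membered aromatic ring of carbon only and its hydrogen-bond donor can both leave, taking the group from 8 heavy atoms to 1, without a step beyond the scatter. No measurement shown here accounts for this result.

Since the ring and the nitrogen of benzylamino leave together in this one step, their separate contributions cannot be told apart, and a reading at one concentration does not show whether compound 1 and compound 4 would differ in potency. Going by these compounds, whether the reading would also hold with a dimethylamino group, a cyclohexyl ring or a longer alkyl chain on the same carbonyl carbon remains open.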